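Hydroxy to methoxy: from compound 1 to compound 3

The source may hold more compounds than are shown below. What is called first, only, known or untested is meant among the compounds shown, and "the series" means these compounds.

Measured in a functional assay on MCF7 cells (Homo sapiens) for inhibition, read by MTT assay, with a stated time of 2 days; a higher number here means a weaker inhibitor, a lower number a stronger inhibitor:
- compound 1 `Nc1ccc(/C=C/c2cccc(O)c2)cc1`: 24.8 ug/mL
- compound 2 `COc1ccc(/C=C/c2cccc(O)c2)cc1`: 21 ug/mL

In this assay, within the data shown here, compound 1 has only one measured neighbour, and the two values lie within the scatter of each other: a 1.2-fold lower number from compound 1 to compound 2 (0.07 log units; within the scatter). Compound 3 `COc1cccc(/C=C/c2ccc(N)cc2)c1` keeps the amino group of compound 1 and differs from it by methyl in place of hydrogen on an oxygen on an aromatic ring, or hydroxy to methoxy.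

Among the measured compounds shown here, no measured step makes this exact change. The nearest evidence is a 1.2-fold lower number from compound 1 to compound 2 (0.07 log units; within the scatter), which is methoxy in place of amino on an aromatic carbon. That step also brings in a methoxy group, but compound 2 keeps the hydroxy that compound 3 loses, so it bears on the change only indirectly. On this thin basis, no step beyond the scatter is expected in this assay, in either direction.

The estimated step is a 1.1-fold lower number from compound 1 to compound 3 (0.05 log units; within the scatter). For compound 3 the expected value is 22 ug/mL, with an estimated range of 10 ug/mL to 48 ug/mL.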

Compound 3, half-maximal inhibitory concentration: 52 ug/mL
Estimate against measurement, compound 3: 2.4-fold (0.37 log units) below; the whole stated range lies below it.
By their numbers in this assay, from the lowest: compounds 2 and 1 (each within the scatter of the next); then compound 3.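

In this assay, among these compounds, methyl in place of hydrogen on an oxygen on an aromatic ring, with the amino group of compound 1 kept, gives a 2.1-fold higher number from compound 1 to compound 3 (0.32 log units; beyond the scatter) and so moves towards a weaker inhibitor; the step is modest, but it is the first in this short series to pass the scatter. Among the compounds shown here, the only earlier step, a 1.2-fold lower number from compound 1 to compound 2 (0.07 log units; within the scatter) as the change of amino to methoxy, lies within the scatter and leaves the hydroxy untouched, so this result is the first sign that the hydroxy place responds to a change as small as one added methyl. Nothing measured here gives a reason for this step.

The reading rests on one pair, and it cannot separate loss of the hydroxy hydrogen from the presence of the added methyl; an ethoxy group, a longer chain on the same oxygen or an amine in place of the hydroxy would bear on that. Also open, going by these compounds, is whether hydroxy to methoxy gives a step of similar size when the amino group is replaced by methoxy, as in compound 2.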